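Replacing the aryl group with methyl on a shared core

A few compounds are considered here, and "the series" means these few. Any claim that something is new, unique, unknown or untested is made for them only; others in the source may bear on it.

Measured in a functional assay on HepG2 cells (Homo sapiens) for antiproliferative activity; on this read-out higher numbers stand for weaker inhibition and lower numbers for stronger inhibition:
compound 1 `C/C(=N\Nc1nc(-c2ccc(Br)cc2)cs1)c1cc2ccccc2o1` gives 27700 nM
compound 2 `COc1ccc(-c2csc(N/N=C(\C)c3cc4ccccc4o3)n2)cc1` gives 15700 nM
compound 3 `C/C(=N\Nc1nc(-c2ccccc2)cs1)c1cc2ccccc2o1` gives 10300 nM

Among these three, compound 2 holds the second highest number; its neighbours lie close on either side, with compound 3 at a 1.5-fold lower number from compound 2 to compound 3 (0.18 log units; within the scatter) and compound 1 at a 1.8-fold lower number from compound 1 to compound 2 (0.25 log units; within the scatter), both within the scatter. The step from compound 2 to compound 4 `C/C(=N\Nc1nc(C)cs1)c1cc2ccccc2o1` is methyl in place of 4-methoxyphenyl on an aromatic carbon. The steps measured so far bear on it only loosely: they swap the substituent on the six-membered ring (a 2.7-fold lower number from compound 1 to compound 3 (0.43 log units; beyond the scatter) being the largest of them) but none removes that ring altogether. Since all three variations of that ring left the numbers within a narrow band, and the change to compound 4 is much deeper, a modest step in this assay is expected, more likely toward weaker inhibition, with a wide uncertainty. For compound 4 the estimate is 22000 nM with a range of 7000 nM to 70000 nM, which means an expected step of a 1.4-fold higher number from compound 2 to compound 4 (0.15 log units; within the scatter).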

Compound 4, half-maximal inhibitory concentration: 4000 nM
For compound 4 the middle estimate is 5.5-fold (0.74 log units) above the measured one, outside the stated range (below it).
By their numbers in this assay, from the lowest: compound 4; then compounds 3, 2 and 1 (each within the scatter of the next, the first and the last beyond it).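

In this assay, for the compounds shown here, the earlier compounds changed only the substituent on the six-membered aromatic ring, whereas methyl in place of the whole aryl group gives stronger inhibition against each of the three aryl partners (a 3.9-fold lower number from compound 2 to compound 4 (0.59 log units; beyond the scatter); a 2.6-fold lower number from compound 3 to compound 4 (0.41 log units; beyond the scatter); a 6.9-fold lower number from compound 1 to compound 4 (0.84 log units; beyond the scatter)). An aryl group on this aromatic carbon is therefore not required for activity among these four compounds, and compound 4 has the lowest number, beyond the scatter of each of the others. No measurement at hand explains why methyl outperforms the aryl groups here.

As far as these compounds go, it remains open whether this gain is specific to methyl or would extend to ethyl, a longer chain, an amine or a carboxylic acid at the same position. A single cell line also leaves open whether the order of the four compounds holds elsewhere.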